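Carbamate ester variation on the shared core

The compounds below may be only part of what the source reports. "The series", "measured", "known", "first", "only" and "open" are said of these compounds alone.

Measured so far:
- compound 1 `Cc1nc(S(C)(=O)=O)ccc1Oc1ncnc(OC2CCN(C(=O)OC(C)(C)C#N)CC2)c1F`: 1320 nM
- compound 2 `Cc1nc(S(C)(=O)=O)ccc1Oc1ncnc(OC2CCN(C(=O)OC(C)F)CC2)c1F`: 315 nM
- compound 3 `Cc1nc(S(C)(=O)=O)ccc1Oc1ncnc(OC2CCN(C(=O)O[C@@H](C)C(F)(F)F)CC2)c1F`: 109 nM

In a functional assay on isolated protein for inhibition of Glucose-dependent insulinotropic receptor (Rattus norvegicus), read by HTRF and cAMP accumulation (a higher number here means that more compound is needed for the effect, a lower number that less compound is needed), compound 3 gives the lowest number of the three, with compound 2 nearest and compound 1 furthest. Compound 4 `Cc1nc(S(C)(=O)=O)ccc1Oc1ncnc(OC2CCN(C(=O)OC3COC3)CC2)c1F` differs from compound 3 by oxetan-3-yl in place of 1-(trifluoromethyl)ethyl on an oxygen next to a carbonyl group. Among the measured compounds shown here, no measured step exchanges an open chain for a ring on this oxygen, so the bearing steps are indirect: a 12-fold lower number from compound 1 to compound 3 (1.08 log units; beyond the scatter) and a 2.9-fold lower number from compound 2 to compound 3 (0.46 log units; beyond the scatter), both beyond the scatter, show that the group on this oxygen moves the number in this assay by a modest to large amount. Given that compound 3 holds the best value, the step from compound 3 to compound 4 is expected to be a modest rise, a 5.5-fold higher number from compound 3 to compound 4 (0.74 log units; beyond the scatter). The estimate for compound 4 in this assay is 600 nM, with a range from 200 nM to 2000 nM.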

Compound 4, half-maximal effective concentration: 2500 nM
Compound 4: middle estimate off by 4.2-fold (0.62 log units), on the low side, outside the stated range (above it).
By their numbers in this assay, from the lowest: compound 3; then compound 2; then compounds 1 and 4 (each within the scatter of the next).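

Oxetan-3-yl is the only ring on this oxygen, and it gives up the gain held by the fluorinated open chains, with a 23-fold higher number from compound 3 to compound 4 (1.36 log units; beyond the scatter) and a 7.9-fold higher number from compound 2 to compound 4 (0.90 log units; beyond the scatter) in this assay. Against 1-cyano-1-methylethyl, a 1.9-fold higher number from compound 1 to compound 4 (0.28 log units; within the scatter) leaves the two groups unseparated, so the ring and this open chain cannot be told apart here. Nothing available accounts for these steps.

From the compounds shown here alone, whether the ring itself or its oxygen drives the step remains open; cyclobutyl on the same oxygen would separate the two. Tetrahydrofuran-3-yl and the other stereoisomer of 1-(trifluoromethyl)ethyl also remain open.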